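The compounds below may be only part of what the source reports. "The series", "measured", "known", "first", "only" and "open" are said of these compounds alone.

Compound 1 `CC(C)COc1ccc(NC(=O)CCCCCCCSc2nnc(Cc3nn(C)c(=O)c4ccccc34)n2C)cc1` is the reference point of this small set. In an assay on isolated protein (Mus musculus) for inhibition of IL15-IL15 receptor (Homo sapiens), read by resazurin assay, with stated times of 30 min and 2.5 days (on this read-out higher numbers stand for weaker inhibition and lower numbers for stronger inhibition), compound 1 gives 4800 nM, the lowest of the two numbers shown. Compound 2 `Cn1c(Cc2nn(C)c(=O)c3ccccc23)nnc1SCCCC(=O)Nc1ccc(Cl)cc1Cl`, which carries a 2,4-dichlorophenyl on the amide nitrogen and a shorter chain between the sulfur and the carbonyl, gives 9800 nM in this assay, a step up from compound 1 that lies beyond the usual scatter. Compound 3 `CN(C(=O)CSc1nnc(Cc2nn(C)c(=O)c3ccccc23)n1C)c1ccc(Cl)cc1Cl`, with the shortest chain and a methyl on the amide nitrogen, is recorded in this assay only as a limit, > 30000 nM, and not as a number. The limit is the limit of > 30000 nM in this assay, at which 1 of the 3 values shown sits.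

Compound 4 `Cn1c(Cc2nn(C)c(=O)c3ccccc23)nnc1SCCCCCCCC(=O)Nc1ccc(Cl)cc1Cl` keeps the long chain of compound 1 and differs from it only at the aryl amide: 2,4-dichlorophenyl in place of 4-(isobutoxy)phenyl on an amide-type nitrogen. Within the data shown here, no measured pair isolates this aryl swap, so the size of the step cannot be read off directly; compound 2 shows that the 2,4-dichlorophenyl amide with a short chain remains a measurable inhibitor. The step of a 1.3-fold higher number from compound 1 to compound 4 (0.10 log units; within the scatter) is therefore expected to be small, in either direction, and probably not beyond the scatter. Compound 4 is estimated at 6000 nM in this assay, with a plausible range from 2000 nM to 20000 nM.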

Compound 4, half-maximal inhibitory concentration: 1900 nM
Compound 4: middle estimate off by 3.2-fold (0.50 log units), on the high side, outside the stated range (below it).
By their numbers in this assay, from the lowest: compound 4; then compound 1; then compound 2. At a limit, above all of these: compound 3.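

With the long chain held fixed, the aryl group on the amide-type nitrogen can now be judged on its own: in this assay, 2,4-dichlorophenyl in place of 4-(isobutoxy)phenyl gives a 2.5-fold lower number from compound 1 to compound 4 (0.40 log units; beyond the scatter), a modest gain in inhibition. Among these compounds, this shows that the isobutoxy group is not required at this position and that the smaller 2,4-dichlorophenyl, which has no hydrogen-bond acceptor, serves at least as well here, something the earlier compounds could not show since none of them shared a chain with compound 1. The compounds shown give no measured reason for this step.

From the compounds shown here alone, it remains open which part of the change carries the gain, since a phenyl with a single chlorine, an unsubstituted phenyl or a 4-(isobutoxy)phenyl on the short chain of compound 2 would each separate the contributions. Also open, going by these compounds, is how the 2,4-dichlorophenyl amide responds to further changes in the linker, such as a still longer chain, an amine or a carboxylic acid placed within it, or a methyl on the amide nitrogen with the long chain kept.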